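Series notes: chain extension on compound 2

The source may report more compounds than this note shows. Statements on the series, on what has been measured and on what is new or still open speak of the compounds shown alone.

Three compounds of the shared core have numbers in a functional assay on EL4 cells (Mus musculus) for antiproliferative activity, read by sulforhodamine B assay, with a stated time of 48 h; on this read-out lower numbers stand for stronger inhibition and higher numbers for weaker inhibition. Compound 1 `C[C@H]1N=C2C[C@H]3C[C@H](C3(C)C)[C@@]2(C)OC1=O` gives 27000 nM. Compound 2 `C[C@@H]1N=C2C[C@@H]3C[C@@H](C3(C)C)[C@]2(C)OC1=O`, its mirror image, gives 145000 nM. Compound 3 `CC1(C)[C@@H]2CC3=NCC(=O)O[C@@]3(C)[C@H]1C2`, which lacks the methyl on the saturated ring carbon, gives 19000 nM. Compound 2 stands highest of the three: the step of a 5.4-fold higher number from compound 1 to compound 2 (0.73 log units; beyond the scatter) rests on (the fact that compounds 1 and 2 differ only in the configuration as drawn), and the step of a 7.6-fold lower number from compound 2 to compound 3 (0.88 log units; beyond the scatter) shows that removing the methyl from compound 2 moves the number the other way.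

Compound 4 `CC(C)(C)OC(=O)CC[C@@H]1N=C2C[C@@H]3C[C@@H](C3(C)C)[C@]2(C)OC1=O` is the next member: (tert-butoxycarbonyl)methyl in place of hydrogen on a saturated chain carbon bound to a saturated ring carbon. Neither measured step bears directly on this change. The mirror-image step from compound 1 to compound 2 alters no group, and the step from compound 2 to compound 3 removes a methyl rather than extending one. The two measured steps show that the series responds to small changes at this part of the core in both directions, so a shift beyond the scatter is plausible for compound 4, but its direction cannot be read from the numbers.

Within the data shown here, with no guiding step, compound 4 is expected near the value of compound 2, the expected step being a 2.1-fold lower number from compound 2 to compound 4 (0.32 log units; beyond the scatter). The estimate for compound 4 is 70000 nM, with a range from 15000 nM to 300000 nM.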

Compound 4, half-maximal inhibitory concentration: 36000 nM
Compound 4: the middle estimate sits 1.9-fold (0.29 log units) above what was measured; low and high end bracket the measured number.
By their numbers in this assay, from the lowest: compounds 3, 1 and 4 (each within the scatter of the next); then compound 2.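

The new step in this assay is a 4.0-fold lower number from compound 2 to compound 4 (0.61 log units; beyond the scatter), so this position accepts (tert-butoxycarbonyl)methyl in place of hydrogen on a saturated chain carbon bound to a saturated ring carbon, and the number falls rather than rises. The earlier steps shown here covered only a mirror-image change and the removal of the methyl, whereas this one adds an extension of that methyl, and both removal in compound 3 and extension in compound 4 give lower numbers than compound 2. Nothing in the data shown bears on what lies behind this step.

Still open, as far as these compounds go, is whether the step belongs to the tert-butyl ester or to the added chain as such: the matching carboxylic acid, a primary amide or a plain propyl chain at this place would separate the two. Also open, from the compounds shown here alone, is whether the same (tert-butoxycarbonyl)methyl group on the mirror-image form, compound 1 at 27000 nM, moves the number in the same way.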